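Chloro on the phenyl ring: compound 2 to compound 3

This account rests on a few compounds, and the source may have more. Where it says the series, first, only, none or still open, it means among the compounds named here.

Working notes on the series. Two members have so far been tested in a toxicity assay on MCF7 cells (Homo sapiens) for cytotoxicity, read by MTT assay; a lower number here means a stronger inhibitor of growth, a higher number a weaker inhibitor of growth. Compound 1, `C/C(=N\NC(N)=S)c1sc(C)nc1C`, returns only a limit of the assay in this assay at > 100 ug/mL. Compound 2, `C/C(=N\Nc1nc(-c2ccccc2)cs1)c1sc(C)nc1C`, likewise returns only a limit in this assay at > 100 ug/mL. Compound 2 therefore stands at the edge of what the assay reports, with no number of its own; both values sit there, as the limit of > 100 ug/mL in this assay, at which 2 of the 2 values shown sit, records. Compound 3, `C/C(=N\Nc1nc(-c2ccc(Cl)cc2)cs1)c1sc(C)nc1C`, remains to be measured in this assay. It differs from compound 2 by chloro in place of hydrogen on an aromatic carbon, para to a large group. Among the compounds with values here, no measured step exists between the two tested compounds, so the expected step is a step that the limit leaves unreadable from compound 2 to compound 3, not beyond the scatter in either direction. Compound 3 is expected to give about 120 ug/mL, within 40 ug/mL to 400 ug/mL, most probably again as a limit rather than a number.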

Compound 3, concentration for 50% growth inhibition: > 100 ug/mL
Compound 3 gave a limit, no number; the forecaster's own chance of this, stated with the estimate: 80%; the middle value lies beyond the limit too.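

No step can be read from compound 2 to compound 3 in this assay, because both give only a limit and no number: the limit of > 100 ug/mL in this assay, at which 3 of the 3 values shown sit.

The compounds shown leave open whether phenyl to 4-chlorophenyl alters growth inhibition in this assay at all.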